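Pyridin-2-yl in place of 4-chlorophenyl on the amide

The source may hold more compounds than are shown below. What is called first, only, known or untested is meant among the compounds shown, and "the series" means these compounds.

Measured in an ADME assay on Vero cells (Chlorocebus sabaeus) for cytotoxicity, read by MTT assay, with a stated time of 72 h; on this read-out higher numbers stand for an effect only at larger amounts of compound and lower numbers for an effect already at smaller amounts:
compound 1 `O=C(Nc1nc(-c2ccccn2)cs1)c1cccc(Br)c1`: 16100 nM
compound 2 `O=C(Nc1nc(-c2ccccn2)cs1)c1ccc(Br)cc1`: 4700 nM
compound 3 `O=C(Nc1nc(-c2ccccn2)cs1)c1ccc(Cl)cc1`: "not determined" (no result reported)
compound 4 `O=C(Nc1nc(-c2ccccn2)cs1)c1ccccn1`: not yet measured

All four compounds share the core of compound 1 and differ only in the group on the carbonyl carbon. As far as these compounds go, compound 3 stands without a single number in this assay, so its place among the measured values is unknown. Compound 4 differs from compound 3 by pyridin-2-yl in place of 4-chlorophenyl on a carbonyl carbon.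

Among the compounds with values here, the only measured step, a 3.4-fold lower number from compound 1 to compound 2 (0.53 log units; beyond the scatter), moves a bromine from one position of the phenyl ring to another and does not touch the exchange of a 4-chlorophenyl for a pyridin-2-yl, so it does not bear on the step from compound 3 to compound 4. No expectation of size or direction can therefore be drawn from it; only the span of numbers for compound 1 and compound 2 gives a frame. Within that frame, compound 4 is estimated at 10000 nM, with an expected range of 2000 nM to 50000 nM.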

Compound 4, half-maximal effective concentration: 5400 nM
Compound 4: the middle estimate sits 1.9-fold (0.27 log units) above what was measured, within the range that was stated.
By their numbers in this assay, from the lowest: compounds 2 and 4 (each within the scatter of the next); then compound 1.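

In this assay the place on the carbonyl carbon also takes a ring with a hetero atom: pyridin-2-yl in place of 4-bromophenyl gives a 1.1-fold higher number from compound 2 to compound 4 (0.06 log units; within the scatter) and thus no change beyond the scatter. Pyridin-2-yl in place of 3-bromophenyl gives a 3.0-fold lower number from compound 1 to compound 4 (0.47 log units; beyond the scatter) and so matches the step seen with 4-bromophenyl, which leaves compound 1 apart from the other two measured compounds. The exchange of 4-chlorophenyl for pyridin-2-yl itself cannot be read, as compound 3 has no number here.

No measurement among those given accounts for these numbers. As far as these compounds go, it stays open how this read-out would respond to an amine or a carboxylic acid on the ring at this place, or to a longer chain in place of the ring.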